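Sulfonyl Chain Variants of a Cationic Oxime: Lipophilicity

The source may hold more compounds than are shown below. What is called first, only, known or untested is meant among the compounds shown, and "the series" means these compounds.

Compound 1 `CCN(CC)CCCn1cc[n+](C)c1/C=N/O`: -2.78
Compound 2 `CCN(CCCn1cc[n+](C)c1/C=N/O)S(C)(=O)=O`: -2.69
Compound 3 `CCN(CCCn1cc[n+](C)c1/C=N/O)S(=O)(=O)C(F)(F)F`: -1.02

In a physicochemical assay for lipophilicity (a lower number here means a more polar compound, a higher number a more lipophilic compound), compound 1 gives the lowest of the three numbers. Compound 2 stands nearest to it, the step from compound 1 to compound 2 being a number 0.09 log units higher from compound 1 to compound 2 (within the scatter). Compound 3 stands furthest, with a number 1.76 log units higher from compound 1 to compound 3 (beyond the scatter), and the move from compound 2 to compound 3 is likewise large, at a number 1.67 log units higher from compound 2 to compound 3 (beyond the scatter).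

Compound 4 `C[n+]1ccn(CCCCS(C)(=O)=O)c1/C=N/O` is not yet measured in this assay. It differs from compound 1 in one place: (methylsulfonyl)methyl in place of diethylamino on a saturated chain carbon, three bonds along the chain from an aromatic nitrogen. Among the compounds with values here, of the measured steps, the one from compound 1 to compound 2 bears most closely on it, since a methylsulfonyl group enters there too and that step stayed within the scatter. The large steps to compound 3 both involve a trifluoromethyl group, which compound 4 does not carry, so they are not expected to be reproduced. The step from compound 1 to compound 4 is therefore estimated as a number 0.28 log units higher from compound 1 to compound 4 (within the scatter), small and not clearly beyond the scatter. Compound 4 is expected to give about -2.5, within a range of -3.1 to -1.9.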

Compound 4, distribution coefficient: -3.4
Beside the measured number, compound 4's estimate is 0.90 log units above it; the whole stated range lies above it.
By their numbers in this assay, from the lowest: compound 4; then compounds 1 and 2 (each within the scatter of the next); then compound 3.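

In this assay, within the data shown here, putting (methylsulfonyl)methyl in place of diethylamino on a saturated chain carbon, three bonds along the chain from an aromatic nitrogen, gives a number 0.62 log units lower from compound 1 to compound 4 (beyond the scatter) and so opens the first downward step beyond the scatter in this set. A methylsulfonyl group on the amine nitrogen had left the number within the scatter of compound 1, so that earlier step does not carry over to this change at this position. Nothing measured here accounts for the direction of the new step.

Compound 4 loses diethylamino and gains the sulfonyl group in one change, so a plain alkyl chain or a carboxylic acid at the same place would be needed to tell those two parts apart. From the compounds shown here alone, it also remains open whether trifluoromethyl on the sulfonyl sulfur of compound 4 would repeat the rise seen in a number 1.67 log units higher from compound 2 to compound 3 (beyond the scatter) on this shorter side chain.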